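Shortening the Ethyl Group on the Fused Ring of Compound 1

This account rests on a few compounds, and the source may have more. Where it says the series, first, only, none or still open, it means among the compounds named here.

Compound 1: `CCc1ccc2oc(CSc3nnc(CNc4ccccc4)n3CC)nc2c1` — in an assay on isolated protein for inhibition of long-chain fatty acid transport protein 1 (Homo sapiens) (on this read-out higher numbers stand for weaker inhibition and lower numbers for stronger inhibition), compound 1 gives > 1000 nM
Compound 2: `CCn1c(CNc2ccccc2)nnc1SCC(=O)Nc1ccc(C(C)=O)cc1` — in this assay compound 2 gives > 1000 nM
Compound 3: `CCn1c(CNc2ccccc2)nnc1SCC(=O)Nc1ccc(C(=O)OC(C)(C)C)cc1` — in this assay compound 3 gives > 1000 nM

All three measured compounds share the same core. The value of compound 1 in this assay is a limit of the assay, not a number. The values of compound 2 and of compound 3 are likewise limits. Among the compounds with values here, the one measured step, a step that the two limits leave unreadable from compound 2 to compound 3, cannot be read in size or direction, since both of its ends are limits; that is the whole of the evidence, summarised as the limit of > 1000 nM in this assay, at which 3 of the 3 values shown sit.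

Compound 4, `CCn1c(CNc2ccccc2)nnc1SCc1nc2cc(C)ccc2o1`, has yet to be measured. It differs from compound 1 by hydrogen in place of methyl on a saturated chain carbon bound to an aromatic carbon. Within the data shown here, no measured step touches this part of the molecule, so nothing shows how much the read-out moves with it. With compound 1 sitting at a limit, it is expected that compound 4 will sit near or beyond the same limit, most likely again reported only as a limit; the estimate for compound 4 is 3000 nM, with a range from 1000 nM to 10000 nM. The estimated step, a step that the limit leaves unreadable from compound 1 to compound 4, is expected to stay within the scatter of the method, since compound 1 itself gives only > 1000 nM.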

Compound 4, half-maximal inhibitory concentration: > 1000 nM
Compound 4 gave a limit, no number; the forecaster's own chance of this, stated with the estimate: 85%; the middle value is on the limit's open side.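

Within the data shown here, compound 1 and compound 4 are both reported only as limits of the assay, so the change from ethyl to methyl gives no step that can be read in size or direction. The compounds shown leave open how strongly any of them inhibits in this assay, and whether any change to the shared core moves the read-out at all: the limit of > 1000 nM in this assay, at which 4 of the 4 values shown sit.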